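The source may hold more compounds than are shown below. What is called first, only, known or untested is meant among the compounds shown, and "the series" means these compounds.

Within the data shown here, three closely related compounds have numbers so far in a functional assay on P388 cells (Mus musculus) for inhibition (on this read-out lower numbers stand for stronger inhibition and higher numbers for weaker inhibition), and they form a small starting set. Compound 1 `Cc1ccc(/C=C2\CCc3ccccc3C2=O)cc1` gives 17700 nM there, compound 2 `O=C1/C(=C/c2ccc(F)cc2)CCCc2ccccc21` gives 11100 nM there, and compound 3 `O=C1/C(=C/c2cccc(Cl)c2)CCCc2ccccc21` gives 8200 nM on the same read-out. Compound 3 and compound 2 lie within the usual scatter of each other, so these two cannot be ranked, while compound 1 has a higher number than compound 3 by more than the scatter.

Compound 4 `O=C1/C(=C/c2cccc([N+](=O)[O-])c2)CCCc2ccccc21` keeps the core of compound 3 and carries nitro in place of chloro on an aromatic carbon, with nitro in place of chloro on an aromatic carbon as the counted difference. Among the measured compounds shown here, no measured pair here differs in one place only, so nothing shows directly what this swap does on that read-out. The nearest guide is that compound 2 at 11100 nM and compound 3 at 8200 nM sit within the scatter of each other although their substituents differ, so no step beyond the scatter is expected. The estimated step of a 1.2-fold lower number from compound 3 to compound 4 (0.07 log units; within the scatter) is expected to stay within the scatter, with only a slight lean toward a lower number. For compound 4 the estimated value is 7000 nM with an expected range from 2500 nM to 20000 nM in this measurement.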

Compound 4, half-maximal inhibitory concentration: 15800 nM
Compound 4: the middle estimate sits 2.3-fold (0.35 log units) below what was measured; the measured number falls inside the stated range.
By their numbers in this assay, from the lowest: compounds 3, 2, 4 and 1 (each within the scatter of the next, the first and the last beyond it).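

Among these compounds, this is the first pair in the set that differs in one place only, so the swap of chloro for nitro, on an aromatic carbon meta to a large group, can now be read directly: in this assay it amounts to a 1.9-fold higher number from compound 3 to compound 4 (0.28 log units; within the scatter). At this position, then, nitro, which has more heavy atoms than chloro and brings hydrogen-bond acceptors where chloro has none, gives a number that cannot be told apart from that of chloro, and the two groups cannot be ranked on this read-out. Nothing measured alongside these compounds speaks to what lies behind this result.

Among the compounds shown here, this single pair covers only two groups at one position on a shared core, so it cannot say whether a group of another kind, such as an amine, a carboxylic acid or a longer alkyl chain, would take the number beyond the scatter there. It also leaves open whether chloro and nitro would stay this close to each other on another carbon of the same aromatic ring.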